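A few compounds are considered here, and "the series" means these few. Any claim that something is new, unique, unknown or untested is made for them only; others in the source may bear on it.

Working notes on the series. Compound 1 `COc1cc(/C=C/C(=O)Nc2ccccc2)ccc1OCCCN(C)C` gives 1.55 in a physicochemical assay for lipophilicity, using the shake flask method, measured as octanol-water partition, at pH 7.4; on this read-out higher numbers stand for higher lipophilicity and lower numbers for lower lipophilicity. Compound 2 `COc1cc(/C=C/C(=O)Nc2ccccc2)ccc1OCCCCN1CCCCC1` gives 1.61 in this assay. Compound 3 `COc1cc(/C=C/C(=O)Nc2ccccc2)ccc1OCCCCCCN(C)C` gives 1.69 in this assay, the upper figure of the three, though its steps to both other compounds stay within the scatter. Compound 4 `COc1cc(/C=C/C(=O)Nc2ccccc2)ccc1OCCCCCCCCN(C)C` differs from compound 3 by 2-(dimethylamino)ethyl in place of dimethylamino on a saturated chain carbon, six bonds along the chain from an oxygen on an aromatic ring. Among the measured compounds shown here, the steps that bear on this are chain lengthenings at the same position: a number 0.14 log units higher from compound 1 to compound 3 (within the scatter) and a number 0.08 log units higher from compound 2 to compound 3 (within the scatter), both within the scatter, as is a number 0.06 log units higher from compound 1 to compound 2 (within the scatter). A further lengthening is therefore expected to give a step of a number 0.11 log units higher from compound 3 to compound 4 (within the scatter) in this assay, upward if anything, and not beyond the scatter. Compound 4 is estimated at 1.8 in this assay, in the range 1.5 to 2.15.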

Compound 4, partition coefficient: 1.74
Estimate against measurement, compound 4: 0.06 log units above, within the range that was stated.
By their numbers in this assay, from the lowest: compounds 1, 2, 3 and 4 (each within the scatter of the next).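

In this assay the change at this place, six bonds along the chain from an oxygen on an aromatic ring, gives a number 0.05 log units higher from compound 3 to compound 4 (within the scatter) and adds no measurable separation. Even the widest span in the series, a number 0.19 log units higher from compound 1 to compound 4 (within the scatter) and alongside it a number 0.13 log units higher from compound 2 to compound 4 (within the scatter) for the piperidin-1-yl compound, stays unresolved, so these four compounds cannot be told apart on this read-out. No measurement on hand speaks to why the read-out stays this flat.

On these data alone, whether a longer chain would leave the scatter remains open. So does the effect of a terminal carboxylic acid or morpholine in place of the amines shown.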